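Swapping nitro for bromo in compound 3

This account rests on a few compounds, and the source may have more. Where it says the series, first, only, none or still open, it means among the compounds named here.

Compounds measured so far in an ADME assay on MT4 cells (Homo sapiens) for cytotoxicity, read by MTT assay, with a stated time of 5 days (a lower number here means that less compound is tolerated, a higher number that more compound is tolerated), are these

- compound 1 `Cc1cc(C#N)cc(C)c1Oc1nc(NC2CCCN(Cc3ccc(S(N)(=O)=O)cc3)C2)nc2ccsc12` gives 1170 nM
- compound 2 `Cc1cc(C#N)cc(C)c1Oc1nc(NC2CCCN(Cc3ccc(C(N)=O)cc3)C2)nc2ccsc12` gives 19500 nM
- compound 3 `Cc1cc(C#N)cc(C)c1Oc1nc(NC2CCC(NCc3ccc([N+](=O)[O-])cc3)CC2)nc2ccsc12` gives 54400 nM

Of these three, compound 3 has the highest number at 54400 nM. The nearest is compound 2 at 19500 nM and the furthest is compound 1 at 1170 nM.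

Compound 4 `Cc1cc(C#N)cc(C)c1Oc1nc(NC2CCC(NCc3ccc(Br)cc3)CC2)nc2ccsc12` has not been measured yet. It differs from compound 3 in one group: bromo in place of nitro on an aromatic carbon.

Within the data shown here, only one measured step involves a similar single swap: a 17-fold higher number from compound 1 to compound 2 (1.22 log units; beyond the scatter), with carbamoyl in place of sulfamoyl on an aromatic carbon. That step is large, so one swapped group can matter a great deal here. However, compounds 1 and 2 differ from compound 3 elsewhere as well, and neither carries nitro or bromo. The step therefore hints at size but says little about direction. Compound 3 already sits at the top with 54400 nM, so a moderate fall is expected rather than a further rise. The expected change is a 2.7-fold lower number from compound 3 to compound 4 (0.43 log units; beyond the scatter), with a wide margin of doubt. Compound 4 is estimated at 20000 nM, within an expected range from 5000 nM to 80000 nM.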

Compound 4, half-maximal cytotoxic concentration: 3450 nM
Compound 4: middle estimate off by 5.8-fold (0.76 log units), on the high side, outside the stated range (below it).
By their numbers in this assay, from the lowest: compound 1; then compound 4; then compound 2; then compound 3.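

In this assay, among these compounds, changing 4-nitrobenzyl to 4-bromobenzyl gives a 16-fold lower number from compound 3 to compound 4 (1.20 log units; beyond the scatter) and so turns the best-tolerated compound so far into one of the less tolerated, which shows that this aromatic carbon, para to a large group, strongly affects the number even with the rest of the molecule unchanged. Among the compounds shown here, until now, the only single-group step was a 17-fold higher number from compound 1 to compound 2 (1.22 log units; beyond the scatter) and it went upward, so the new step adds a large change in the opposite direction, showing that a swap on an aromatic carbon can move the number a long way either up or down. No measurement at hand accounts for the fall in tolerated concentration.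

As far as these compounds go, it remains open whether the fall comes from bromo entering or from nitro leaving, which other groups at this position, such as an amine, a methoxy or a carboxylic acid, would help to separate. It is also unknown whether the same swap would have a similar effect on the differently attached benzyl group of compound 1 and compound 2.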